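This account rests on a few compounds, and the source may have more. Where it says the series, first, only, none or still open, it means among the compounds named here.

Series notes. Compound 1 `CCCSc1nc(N/N=C/c2ccccc2F)c2nnn(Cc3ccccc3)c2n1`, compound 2 `CCCSc1nc(N/N=C/c2ccc(C)cc2)c2nnn(Cc3ccccc3)c2n1` and compound 3 `CCCSc1nc(N/N=C/c2ccc(Cl)cc2)c2nnn(Cc3ccccc3)c2n1` share one core and differ only in the group on a carbon with a double bond to nitrogen. In a functional assay on ECa-109 cells (Homo sapiens) for antiproliferative activity, read by MTT assay, with a stated time of 72 h (a lower number here means a stronger inhibitor, a higher number a weaker inhibitor), compound 1 reports only a limit, > 64000 nM. In this assay compound 2 likewise gives a limit, > 64000 nM. In this assay compound 3 also sits at a limit, > 64000 nM. The steps a step that the two limits leave unreadable from compound 1 to compound 2, a step that the two limits leave unreadable from compound 1 to compound 3 and a step that the two limits leave unreadable from compound 2 to compound 3 cannot be sized because all three values rest at the limit of > 64000 nM in this assay, at which 3 of the 3 values shown sit. Compound 4 `CCCSc1nc(N/N=C/c2ccc(N(C)C)cc2)c2nnn(Cc3ccccc3)c2n1` differs from compound 3 by dimethylamino in place of chloro on an aromatic carbon. Among the measured compounds shown here, no measured step bears on this change, so no direction in this assay can be read. Compound 4 is expected to stay at the limit, the step that the limit leaves unreadable from compound 3 to compound 4 being estimated as none beyond the scatter. Compound 4 is estimated at 80000 nM, between 20000 nM and 300000 nM.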

Compound 4, half-maximal inhibitory concentration: 20000 nM
Compound 4: middle estimate off by 4.0-fold (0.60 log units), on the high side; measured number inside the range.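

In this assay, among the compounds shown here, dimethylamino on this aromatic carbon gives the only value of the four not resting at a limit, a change that reads as an at least 3.2-fold lower number from compound 3 to compound 4 (0.50 log units; beyond the scatter) and as an at least 3.2-fold lower number from compound 2 to compound 4 (0.50 log units; beyond the scatter) and as an at least 3.2-fold lower number from compound 1 to compound 4 (0.50 log units; beyond the scatter) for the whole aryl group. None of these steps can be sized beyond its bound because compounds 1, 2 and 3 all rest at a limit: the limit of > 64000 nM in this assay, at which 3 of the 4 values shown sit.

Going by these compounds, whether a cyclic amine such as morpholine or a plain amino group on the same aromatic carbon also lowers the number stays open.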